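This account rests on a few compounds, and the source may have more. Where it says the series, first, only, none or still open, it means among the compounds named here.

Values in a functional assay on MDA-MB-435S cells (Homo sapiens) for cytotoxicity, read by MTT assay, with a stated time of 72 h; a lower number here means a stronger inhibitor, a higher number a weaker inhibitor:
compound 1 `Cc1cc(C)nc(SCc2cc(=O)c3cc(Cl)ccc3o2)n1`: > 25000 nM.
compound 2 `Cc1nnc(SCc2cc(=O)c3cc(Cl)ccc3o2)o1`: > 25000 nM.
compound 3 `Cc1nnc(SCc2cc(=O)c3ccccc3o2)o1`: > 25000 nM.

The value of compound 1 is only a limit of this assay, not a number. The value of compound 2 is likewise a limit. The value of compound 3 is also a limit. (the limit of > 25000 nM in this assay, at which 3 of the 3 values shown sit).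

Compound 2 and compound 3 differ by hydrogen in place of chloro on an aromatic carbon; the step that the two limits leave unreadable from compound 2 to compound 3. Compound 4 `Cc1cc(C)nc(SCc2cc(=O)c3ccccc3o2)n1` differs from compound 1 by hydrogen in place of chloro on an aromatic carbon, the same change at the same place. The difference between the core of compound 1 and that of compound 2 is not broken down here.

From compound 1 to compound 4 the expected step is a step that the limit leaves unreadable from compound 1 to compound 4, resting on the unreadable step that the two limits leave unreadable from compound 2 to compound 3 and on (the limit of > 25000 nM in this assay, at which 3 of the 3 values shown sit). Compound 4 is therefore estimated at 40000 nM in this assay, with a range from 15000 nM to 150000 nM.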

Compound 4, half-maximal inhibitory concentration: > 25000 nM
Compound 4: a limit, no number; the forecaster's own chance of this, stated with the estimate: 85%; the middle value lies beyond the limit too.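

No step can be read between compound 1 and compound 4, since both values are only limits: the limit of > 25000 nM in this assay, at which 4 of the 4 values shown sit.

The compounds shown leave open whether any change to the shared core would give a readable value.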